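Sulfonamide aryl swap on a thiazoloimidazole pyrimidine series

This account rests on a few compounds, and the source may have more. Where it says the series, first, only, none or still open, it means among the compounds named here.

Three analogues of one shared core carry an arylsulfonamide on a short chain off the pyrimidine amine. Compound 1 `O=S(=O)(NCCCNc1nccc(-c2c(-c3cccc(F)c3)nc3sccn23)n1)c1cccc(F)c1` has a three-carbon chain and a 3-fluorophenylsulfonyl group; in a functional assay on A-375 cells (Homo sapiens) for cytotoxicity, read by MTT assay (a lower number here means a stronger inhibitor, a higher number a weaker inhibitor), compound 1 gives 13700 nM. Compound 2 `O=S(=O)(NCCNc1nccc(-c2c(-c3cccc(F)c3)nc3sccn23)n1)c1ccc(Cl)cc1` shortens the chain and carries a 4-chlorophenylsulfonyl group; in this assay compound 2 gives 18600 nM. Compound 3 `Cc1ccc(S(=O)(=O)NCCNc2nccc(-c3c(-c4cccc(F)c4)nc4sccn34)n2)cc1` keeps the short chain with a 4-methylphenylsulfonyl group; in this assay compound 3 gives 15400 nM. Compound 3 stands second highest of the three numbers, and every step among them is within the scatter: a 1.4-fold higher number from compound 1 to compound 2 (0.13 log units; within the scatter), a 1.1-fold higher number from compound 1 to compound 3 (0.05 log units; within the scatter), a 1.2-fold lower number from compound 2 to compound 3 (0.08 log units; within the scatter).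

Compound 4 `O=S(=O)(NCCNc1nccc(-c2c(-c3cccc(F)c3)nc3sccn23)n1)c1cccc(F)c1` differs from compound 3 by 3-fluorophenyl in place of 4-methylphenyl on a sulfonyl sulfur. The nearest measured step is the aryl exchange from compound 2 to compound 3, which stayed within the scatter, and compound 1 already carries the 3-fluorophenylsulfonyl group on a longer chain with a number in the same band. Among the compounds with values here, no measured step on this series has moved this assay beyond the scatter, so no step beyond the scatter is expected here either, in either direction. The step from compound 3 to compound 4 is expected to be a 1.0-fold lower number from compound 3 to compound 4 (0.01 log units; within the scatter). Compound 4 is therefore estimated at 15000 nM in this assay, within the range 7500 nM to 30000 nM.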

Compound 4, half-maximal inhibitory concentration: 14900 nM
The estimate for compound 4 lay 1.0-fold (0.00 log units) above the measured number; measured number inside the range.
By their numbers in this assay, from the lowest: compounds 1, 4, 3 and 2 (each within the scatter of the next).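

With the shorter chain held fixed, three aryl groups on the sulfonyl sulfur can now be read side by side in this assay (a 1.0-fold lower number from compound 3 to compound 4 (0.01 log units; within the scatter); a 1.2-fold lower number from compound 2 to compound 4 (0.10 log units; within the scatter)), and 3-fluorophenyl falls within the scatter of both 4-methylphenyl and 4-chlorophenyl. Within the data shown here, the chain can also be read on its own for the first time, since the earlier steps from compound 1 changed the chain and the aryl group together, whereas here the 3-fluorophenylsulfonyl group stays in place (a 1.1-fold higher number from compound 1 to compound 4 (0.04 log units; within the scatter)), and this shortening also stays within the scatter. The data give no measured account of why neither change shifts the number.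

All four compounds lie within the scatter of one another, so neither the sulfonyl aryl group nor the chain has yet been shown to matter in this assay, and it remains open whether a carboxylic acid or an amine on that aryl ring, or a methyl in place of the whole aryl group, would move the number beyond the scatter. On these data alone, a longer chain than that of compound 1 also remains open, as does any change to the 3-fluorophenyl group on the shared core, which is the same in all four.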